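The source may report more compounds than this note shows. Statements on the series, on what has been measured and on what is new or still open speak of the compounds shown alone.

Three compounds have been measured so far in a functional assay on MCF7 cells (Homo sapiens) for inhibition, read by CCK-8 assay, with a stated time of 72 h (a higher number here means a weaker inhibitor, a lower number a stronger inhibitor), and give these values:

- compound 1 `O=C(/C=C/c1cccnc1)NCCCCCCc1cccc(S(=O)(=O)Nc2ccccc2)c1` gives 0.63 nM
- compound 2 `Cc1ccccc1NS(=O)(=O)c1cccc(CCCCCCNC(=O)/C=C/c2cccnc2)c1` gives 0.226 nM
- compound 3 `CC(C)(C)c1ccc(NS(=O)(=O)c2cccc(CCCCCCNC(=O)/C=C/c3cccnc3)c2)cc1` gives 26.3 nM

Compound 3 has the highest number of the three. Compound 4 `O=C(/C=C/c1cccnc1)NCCCCCCc1cccc(S(=O)(=O)Nc2ccc(C(F)(F)F)cc2)c1` carries trifluoromethyl in place of tert-butyl on an aromatic carbon, para to a large group (trifluoromethyl in place of tert-butyl on an aromatic carbon). Two large steps bring in the tert-butyl group (a 42-fold higher number from compound 1 to compound 3 (1.62 log units; beyond the scatter) and a 120-fold higher number from compound 2 to compound 3 (2.07 log units; beyond the scatter)), while the methyl step is modest (a 2.8-fold lower number from compound 1 to compound 2 (0.45 log units; beyond the scatter)). For the measured compounds named here, no measured step exchanges these two groups directly, so a clear move to a lower number is expected in this assay, short of a full return to compound 1. The estimated step is moderate to large (an 8.8-fold lower number from compound 3 to compound 4 (0.94 log units; beyond the scatter)). Compound 4 is expected at 3 nM (range 0.5 nM to 18 nM).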

Compound 4, half-maximal inhibitory concentration: 67.8 nM
Beside the measured number, compound 4's estimate is 23-fold (1.35 log units) below it; the whole stated range lies below it.
By their numbers in this assay, from the lowest: compound 2; then compound 1; then compound 3; then compound 4.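

In this assay trifluoromethyl does not restore what tert-butyl cost at this place on the ring: the exchange gives a 2.6-fold higher number from compound 3 to compound 4 (0.41 log units; beyond the scatter) and moves further from the parent compounds. Replacing hydrogen with trifluoromethyl gives a 110-fold higher number from compound 1 to compound 4 (2.03 log units; beyond the scatter) and replacing 2-methylphenyl with 4-(trifluoromethyl)phenyl gives a 300-fold higher number from compound 2 to compound 4 (2.48 log units; beyond the scatter) so compound 3 and compound 4 both stand far above compound 1 and compound 2. No measurement shown here explains this result.

Still open, as far as these compounds go, is how a methyl, a fluorine or an amine at this same place would compare with the hydrogen of compound 1.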